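A few compounds are considered here, and "the series" means these few. Any claim that something is new, unique, unknown or untested is made for them only; others in the source may bear on it.

Compound 1, with the structure `COc1ncc(C(F)(F)F)cc1CO[C@H]1[C@H](C(C)(C)C)[C@@H](C(=O)O)N(C(=O)OC(C)C)[C@H]1c1ccccc1`, gives 137 nM in an assay on cells with Cystic fibrosis transmembrane conductance regulator variant F508del (Homo sapiens) as the target, read by voltage clamp, with a stated time of 24 h, in the presence of a further agent that is not named here; a higher number here means that more compound is needed for the effect, a lower number that less compound is needed. Compound 2, with the structure `COc1ncc(C(F)(F)F)cc1CO[C@H]1[C@H](C(C)(C)C)[C@@H](C(=O)O)N(C(=O)[C@@H]2CCCCO2)[C@H]1c1ccccc1`, gives 213 nM in this assay, and compound 3, with the structure `COc1ncc(C(F)(F)F)cc1CO[C@H]1[C@H](C(C)(C)C)[C@@H](C(=O)O)N(C(=O)[C@H]2CCCCO2)[C@H]1c1ccccc1`, gives 346 nM. Among these three numbers compound 2 stands second highest; its nearest neighbour is compound 1 and its furthest is compound 3, and both gaps lie within the scatter. The measured steps are all at the carbonyl carbon: a 1.6-fold higher number from compound 1 to compound 2 (0.19 log units; within the scatter), a 2.5-fold higher number from compound 1 to compound 3 (0.40 log units; beyond the scatter), and a 1.6-fold higher number from compound 2 to compound 3 (0.21 log units; within the scatter), the last a small difference that comes from the fact that compounds 2 and 3 differ only in the configuration as drawn.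

Compound 4, with the structure `COc1ncc(C(F)(F)F)cc1CO[C@H]1[C@H](C(C)(C)C)[C@@H](C(=O)O)N(C(=O)[C@@H]2CCCCO2)[C@H]1c1ccccc1CC(C)C`, is not yet measured. It differs from compound 2 by isobutyl in place of hydrogen on an aromatic carbon. Going by the values given here, none of the measured steps touches that aromatic ring, so no measured step bears directly on this change; what the measured steps do show is that every change tried so far moved the number by only a small or modest amount. On that basis the step from compound 2 to compound 4 is expected to be a 1.0-fold higher number from compound 2 to compound 4 (0.01 log units; within the scatter), with no confident direction. Compound 4 is therefore estimated at 220 nM in this assay, within a range from 60 nM to 800 nM.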

Compound 4, half-maximal effective concentration: 52 nM
The estimate for compound 4 lay 4.2-fold (0.63 log units) above the measured number; the whole stated range lies above it.
By their numbers in this assay, from the lowest: compound 4; then compounds 1, 2 and 3 (each within the scatter of the next, the first and the last beyond it).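

In this assay, putting isobutyl on an aromatic carbon of the six-membered aromatic ring of carbon only, ortho to a large group, gives a 4.1-fold lower number from compound 2 to compound 4 (0.61 log units; beyond the scatter). The earlier compounds shown here differ only at the carbonyl carbon, so they left this ring unexplored; this step shows that the ring position can take a branched carbon chain and that less compound is then needed for the effect, a change beyond the usual scatter of repeated measurements. The result says what happens to the number, but nothing given here explains why it moves in this direction.

With isobutyl as the only group shown at this position, it remains open whether a smaller methyl, a longer chain such as n-hexyl, or an amine or a carboxylic acid would lower the number as well, or whether the same group would do so on another carbon of the ring. On these data alone, it also remains open whether isobutyl would have a similar effect when the carbonyl carries the isopropoxy group of compound 1 or the oxan-2-yl group in the configuration of compound 3.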